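The compounds below may be only part of what the source reports. "The series", "measured", "known", "first", "only" and "open" are said of these compounds alone.

Compound 1 `O=C(c1ccc(F)cc1)N1CC(c2nc(-c3cccc(Cl)c3)no2)C1` carries a 4-fluorophenyl on the carbonyl carbon of the shared core. In an assay on HEK293 cells for positive allosteric modulation of metabotropic glutamate receptor 5 (Homo sapiens), read by FLIPR (a higher number here means that more compound is needed for the effect, a lower number that less compound is needed), compound 1 gives only the limit > 10000 nM. Compound 2 `O=C(c1cccc(F)c1)N1CC(c2nc(-c3cccc(Cl)c3)no2)C1` has a 3-fluorophenyl in that place; in this assay compound 2 likewise gives only the limit > 10000 nM. Compound 3 `COC1CCCN(C(=O)N2CC(c3nc(-c4cccc(Cl)c4)no3)C2)C1` carries a 3-methoxypiperidin-1-yl on the same carbonyl carbon. Compound 3 in this assay also stands at a limit, > 10000 nM. The three steps a step that the two limits leave unreadable from compound 1 to compound 2, a step that the two limits leave unreadable from compound 1 to compound 3 and a step that the two limits leave unreadable from compound 2 to compound 3 have no readable size, since (the limit of > 10000 nM in this assay, at which 3 of the 3 values shown sit).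

Compound 4 `O=C([C@@H]1CC2CCC1C2)N1CC(c2nc(-c3cccc(Cl)c3)no2)C1` is not yet measured; it differs from compound 3 by a group of 7 heavy atoms (7 carbon; 2 five-membered non-aromatic rings of carbon only) in place of a group of 8 heavy atoms (6 carbon, 1 nitrogen, 1 oxygen; one six-membered non-aromatic ring with 1 hetero atom), on a carbonyl carbon. Among the compounds with values here, no measured step touches this change, and none of the measured steps has a size that can be read, so nothing points in either direction. The expectation for compound 4 in this assay is 10000 nM, with a range of 3000 nM to 30000 nM, and most likely once more only a limit. The expected step is a number no higher from compound 3 to compound 4 (the limit leaves the size open), none beyond the scatter.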

Compound 4, half-maximal effective concentration: 98 nM
Compound 4: middle estimate off by 100-fold (2.01 log units), on the high side; the whole stated range lies above it.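

In this assay, the position on the carbonyl carbon now shows a large response: the group with 2 five-membered non-aromatic rings of carbon only gives an at least 100-fold lower number from compound 3 to compound 4 (2.00 log units; beyond the scatter), an at least 100-fold lower number from compound 2 to compound 4 (2.00 log units; beyond the scatter) and an at least 100-fold lower number from compound 1 to compound 4 (2.00 log units; beyond the scatter). The same group replaces both a six-membered aromatic ring of carbon only and a six-membered non-aromatic ring with 1 hetero atom, so the result does not depend on which of these groups serves as the comparison. The steps among compounds 1, 2 and 3 remain unreadable, and the new steps give only a lower bound on size, because the other compounds stand at a limit: the limit of > 10000 nM in this assay, at which 3 of the 4 values shown sit.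

The compounds shown do not separate the contribution of the two-ring carbon frame from that of its defined stereocentre. Going by these compounds, how a cyclohexyl or a tert-butyl group, or the opposite stereoisomer of compound 4, would behave at this position remains open.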